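Adding a 4-Methoxyphenyl Group on Two Related Cores

This account rests on a few compounds, and the source may have more. Where it says the series, first, only, none or still open, it means among the compounds named here.

compound 1 `Cn1nc(-c2ccccc2)c2cc(C(=N)Nc3ccccc3)ncc21`: 17400 nM
compound 2 `CN1CCN(c2ccc(NC(=N)c3cc4cnn(C)c4cn3)cc2)CC1`: 24000 nM
compound 3 `COc1ccc(Cn2nc(-c3ccccc3)c3cc(C(=N)Nc4ccccc4)ncc32)cc1`: 4700 nM

All three were tested in a functional assay on HT-1080 cells (Homo sapiens) for cytotoxicity, read by MTT assay, with a stated time of 72 h; on this read-out lower numbers stand for stronger inhibition and higher numbers for weaker inhibition. Compound 1 and compound 3 share a core and differ only in 4-methoxyphenyl in place of hydrogen on a saturated chain carbon bound to an aromatic nitrogen; that change gave a 3.7-fold lower number from compound 1 to compound 3 (0.57 log units; beyond the scatter). Compound 2 sits on a different core, and the difference between the two cores is not broken down here; its value and that of compound 1 lie within the usual scatter of each other. Compound 4 `COc1ccc(Cn2ncc3cc(C(=N)Nc4ccc(N5CCN(C)CC5)cc4)ncc32)cc1` has not yet been measured. It differs from compound 2 by 4-methoxyphenyl in place of hydrogen on a saturated chain carbon bound to an aromatic nitrogen, the same change at the same place as seen once already. For the measured compounds named here, for compound 4 a step of similar size is expected, a 3.7-fold lower number from compound 2 to compound 4 (0.57 log units; beyond the scatter), because the single earlier example of this change gave a 3.7-fold lower number from compound 1 to compound 3 (0.57 log units; beyond the scatter). Compound 4 is therefore estimated at 6500 nM, expected to fall between 2500 nM and 17000 nM.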

Compound 4, half-maximal inhibitory concentration: 5300 nM
The estimate for compound 4 lay 1.2-fold (0.09 log units) above the measured number; measured number inside the range.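

In this assay, adding the 4-methoxyphenyl group to the core of compound 2 gave a 4.5-fold lower number from compound 2 to compound 4 (0.66 log units; beyond the scatter), so the change carried over to a second core with a step of much the same size. The two steps agree: the same change on two cores in this assay, a 3.7-fold lower number (0.57 log units; beyond the scatter) from compound 1 to compound 3 and a 4.5-fold lower number (0.66 log units; beyond the scatter) from compound 2 to compound 4, 1.2-fold (0.09 log units) apart, within the scatter of two such steps. This rests on just two cores in this assay, so it does not show that the step would hold on further cores, and it does not explain why the numbers fall.

The compounds shown leave open whether the methoxy group matters, as a plain benzyl group would test. They also leave open whether a longer chain or an amine at this place would give a similar step.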